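Compound 3 to compound 4: a step from a limit

The source may hold more compounds than are shown below. What is called first, only, known or untested is meant among the compounds shown, and "the series" means these compounds.

Measured in a functional assay on HEK293 cells (Homo sapiens) for cytotoxicity (a lower number here means that less compound is tolerated, a higher number that more compound is tolerated), each value a limit:
compound 1 `COc1ccc([C@H]2CC(=O)N(c3ccccc3)C2)cc1OC1CCCC1`: > 10000 nM
compound 2 `COc1ccc([C@H]2CC(=O)N(c3cccc(NCC4CCOC4)c3)C2)cc1OC1CCCC1`: > 10000 nM
compound 3 `CCCCNc1cccc(N2C[C@@H](c3ccc(OC)c(OC4CCCC4)c3)CC2=O)c1`: > 10000 nM

Compound 3 has only a limit and no number: > 10000 nM. Compound 4 `COc1ccc([C@H]2CC(=O)N(c3cccc(NS(=O)(=O)c4ccccc4Cl)c3)C2)cc1OC1CCCC1` carries (2-chlorophenyl)sulfonyl in place of butyl on a nitrogen on an aromatic ring, so that butylamino becomes ((2-chlorophenyl)sulfonyl)amino: (2-chlorophenyl)sulfonyl in place of butyl on a nitrogen on an aromatic ring. Within the data shown here, three measured steps bear on this change: a step that the two limits leave unreadable from compound 1 to compound 3, a step that the two limits leave unreadable from compound 2 to compound 3 and a step that the two limits leave unreadable from compound 1 to compound 2. Among the measured compounds shown here, none of them has a size that can be read, and no measured compound carries a sulfonyl group. No step beyond the scatter is expected in this assay for compound 4, in either direction, because of the limit of > 10000 nM in this assay, at which 3 of the 3 values shown sit, shared by compound 1, compound 2 and compound 3. The expected step is a step that the limit leaves unreadable from compound 3 to compound 4. The estimate for compound 4 is 20000 nM, with an expected range of 6000 nM to 60000 nM.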

Compound 4, half-maximal cytotoxic concentration: > 10000 nM
Compound 4 was reported as a limit; the forecaster's own chance of this, stated with the estimate: 80%; the middle value lies beyond the limit too.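

In this assay compound 4 gives > 10000 nM as a limit, not a number. No step among compound 1, compound 2, compound 3 and compound 4 can be read, because all four share that limit: the limit of > 10000 nM in this assay, at which 4 of the 4 values shown sit.

The compounds shown leave open at what concentration any of them becomes cytotoxic, and whether these groups change that concentration.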